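A few compounds are considered here, and "the series" means these few. Any claim that something is new, unique, unknown or untested is made for them only; others in the source may bear on it.

Notes on the series. Compound 3 `CNCc1c(OC)cc(Oc2cccc(Nc3ccccc3)c2)cc1OC` carries a methyl on the amine nitrogen and gives 11900 nM in a functional assay on DLD-1 cells (Homo sapiens) for inhibition, read by MTT assay, with a stated time of 72 h; on this read-out lower numbers stand for stronger inhibition and higher numbers for weaker inhibition; this is the highest of the two numbers seen, with compound 1 `COc1cc(Oc2cccc(Nc3ccccc3)c2)cc(OC)c1CNCc1ccc(Br)cc1`, bearing a 4-bromobenzyl, the nearest at 3520 nM. Compound 2 `COc1cc(Oc2cccc(Nc3ccccc3)c2)cc(OC)c1CNC1CC1` reaches only a limit, > 20000 nM, in this assay. Among the compounds with values here, the steps that bear on the amine substituent are a 3.4-fold higher number from compound 1 to compound 3 (0.53 log units; beyond the scatter), an at least 5.6-fold higher number from compound 1 to compound 2 (0.75 log units; beyond the scatter) and an at least 1.6-fold lower number from compound 2 to compound 3 (0.22 log units; that floor lies within the scatter): the number falls with the 4-bromobenzyl and rises with the cyclopropyl. Compound 4 `COc1cc(Oc2cccc(Nc3ccccc3)c2)cc(OC)c1CNCCNC(C)=O` differs from compound 3 by acetamidomethyl in place of hydrogen on a saturated chain carbon bound to an amine nitrogen. The entering group carries no ring, so the lower number seen for compound 1 at 3520 nM is not expected to carry over; the comparison of compound 2 with compound 3 suggests that a saturated change on this nitrogen moves the number little or upward. The expected step is a 1.0-fold higher number from compound 3 to compound 4 (0.00 log units; within the scatter), not beyond the scatter. Compound 4 is therefore estimated at 12000 nM, between 5000 nM and 30000 nM.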

Compound 4, half-maximal inhibitory concentration: 6010 nM
Compound 4: middle estimate off by 2.0-fold (0.30 log units), on the high side; low and high end bracket the measured number.
By their numbers in this assay, from the lowest: compounds 1, 4 and 3 (each within the scatter of the next, the first and the last beyond it). At a limit, above all of these: compound 2.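

In this assay, the first chain on this amine nitrogen that carries an amide gives a 2.0-fold lower number from compound 3 to compound 4 (0.30 log units; within the scatter), so the acetamidomethyl change is not separated from hydrogen at this saturated chain carbon. The same group, which has no ring, gives a 1.7-fold higher number from compound 1 to compound 4 (0.23 log units; within the scatter), so compound 4 is also not separated from the 4-bromobenzyl of compound 1, although compound 1 and compound 3 do stand apart. The one step beyond the scatter is an at least 3.3-fold lower number from compound 2 to compound 4 (0.52 log units; beyond the scatter), and it is read against a limit for compound 2: the limit of > 20000 nM in this assay, at which 1 of the 4 values shown sits.

Still open, from the compounds shown here alone, is whether a longer chain, or a terminal carboxylic acid or free amine in place of the acetamide, would separate from compound 3. Also open, going by these compounds, is whether a plain benzyl would match compound 1, which would show how much of that number depends on the bromine.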